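Two Weak Cytotoxic Purines and a Halogen Swap

A few compounds are considered here, and "the series" means these few. Any claim that something is new, unique, unknown or untested is made for them only; others in the source may bear on it.

Compound 1: `OC[C@H]1C[C@@H](Cn2cnc3c(-c4ccccc4)ncnc32)c2ccccc21`, 28100 nM
Compound 2: `CC(=O)OCCOCn1cnc2c(Cl)nc(Cl)nc21`, 39300 nM

Of the compounds shown here, two have been tested in an ADME assay on L1210/0 cells (Mus musculus) for cytotoxicity, with a stated time of 48 h; on this read-out higher numbers stand for weaker inhibition and lower numbers for stronger inhibition. Compound 1, `OC[C@H]1C[C@@H](Cn2cnc3c(-c4ccccc4)ncnc32)c2ccccc21`, gives 28100 nM in this assay. Compound 2, `CC(=O)OCCOCn1cnc2c(Cl)nc(Cl)nc21`, gives 39300 nM in this assay. Compound 2 has the higher of the two numbers, but the gap to compound 1 lies within the scatter, so the two compounds show no real difference here. Both compounds sit at weak inhibition.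

Compound 3, `CC(=O)OCCOCn1cnc2c(Cl)nc(I)nc21`, has not yet been measured. It differs from compound 2 in one place: iodo in place of chloro on an aromatic carbon. Going by the values given here, nothing has been measured for this kind of halogen exchange, so there is no step to lean on. With both measured compounds weak, and the change limited to one atom, the expectation for compound 3 is a step from compound 2 that stays within the scatter, in no particular direction, estimated as a 1.1-fold lower number from compound 2 to compound 3 (0.05 log units; within the scatter). Compound 3 is accordingly expected to give about 35000 nM in this assay, with a range from 15000 nM to 90000 nM.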

Compound 3, half-maximal inhibitory concentration: 8600 nM
Beside the measured number, compound 3's estimate is 4.1-fold (0.61 log units) above it, and the stated range ends above it.
By their numbers in this assay, from the lowest: compound 3; then compounds 1 and 2 (each within the scatter of the next).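

In this assay, going by these compounds alone, a single exchange of one heavy atom, iodo in place of chloro, gives a 4.6-fold lower number from compound 2 to compound 3 (0.66 log units; beyond the scatter), the first step in this small set that lies beyond the scatter. This shows that the aromatic carbon between two ring nitrogen atoms is not a silent place in this series: the halogen there changes the read-out even though the count of hydrogen-bond donors and acceptors and the net charge stay the same, and the chloro group meta to it stays in place. No measurement shown here accounts for the size or direction of this step.

Because this is a single step on a single scaffold, the compounds shown leave open whether a bromo or fluoro group, or an amine, at this same carbon would move the number in the same direction, and how far. They also leave open whether iodo in place of the remaining chloro group, or the same exchange with the acetate ester replaced by a carboxylic acid, would give a step of similar size.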